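Saturating one chain double bond: compound 2 to compound 4

This account rests on a few compounds, and the source may have more. Where it says the series, first, only, none or still open, it means among the compounds named here.

Measured in a functional assay on MCF7 cells (Homo sapiens) for antiproliferative activity, read by sulforhodamine B assay, with a stated time of 48 h; on this read-out higher numbers stand for weaker inhibition of growth and lower numbers for stronger inhibition of growth:
- compound 1 `CCCCCCCC/C=C\CCCCCCCC(=O)N1CCCC1`: 5.2 ug/mL
- compound 2 `CCCCC/C=C\C/C=C\CCCCCCCC(=O)N1CCCCC1`: 22.1 ug/mL
- compound 3 `CCCCCCCCCCCCCCCC(=O)N1CCOCC1`: 15.4 ug/mL

Compound 2 at 22.1 ug/mL and compound 3 at 15.4 ug/mL lie within the scatter of each other. Compound 1 at 5.2 ug/mL has a lower number than either, and its gap to compound 2 lies beyond the scatter.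

Compound 4 `CCCCCCCC/C=C\CCCCCCCC(=O)N1CCCCC1` differs from compound 2 by heptyl in place of hept-1-en-1-yl on a saturated chain carbon bound to a double-bonded chain carbon. Among the compounds with values here, no measured pair isolates this change, so the expectation rests on thin evidence. Compound 4 has the same acyl chain as compound 1, which gives 5.2 ug/mL, and the same amide part as compound 2, which gives 22.1 ug/mL. A number between these two is therefore expected. In this assay the expected change is a 2.0-fold lower number from compound 2 to compound 4 (0.30 log units; within the scatter), towards stronger inhibition of growth and close to the edge of the scatter. For compound 4 the estimate is 11 ug/mL, with an expected range of 4.5 ug/mL to 25 ug/mL.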

Compound 4, concentration for 50% growth inhibition: 7.6 ug/mL
Compound 4: the middle estimate sits 1.4-fold (0.16 log units) above what was measured, within the range that was stated.
By their numbers in this assay, from the lowest: compounds 1 and 4 (each within the scatter of the next); then compounds 3 and 2 (each within the scatter of the next).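

In this assay, within the data shown here, the saturation reads as a 2.9-fold lower number from compound 2 to compound 4 (0.46 log units; beyond the scatter) and is the first isolated reading of this change, with heptyl in place of hept-1-en-1-yl moving towards stronger inhibition of growth by a margin beyond the scatter. With the acyl chain held constant, the amide change reads as a 1.5-fold higher number from compound 1 to compound 4 (0.16 log units; within the scatter) and stays within the scatter, so piperidin-1-yl and pyrrolidin-1-yl on a carbonyl carbon cannot be told apart on this chain. No measurement bears on the reason for the chain effect.

Compound 3 still differs from each of the others in more than one place, so its chain and amide part cannot be read separately. The compounds shown also leave open whether a fully saturated octadecanoyl chain or a carboxylic acid at the chain end would keep this level of inhibition.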